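Chain Length at the Sulfonyl Trifluoromethyl Ketone

The compounds below may be only part of what the source reports. "The series", "measured", "known", "first", "only" and "open" are said of these compounds alone.

Compound 2, `CCCCCCCCCCS(=O)(=O)CC(=O)C(F)(F)F`, is the sulfonyl member of the pair measured so far. In an assay on isolated protein for inhibition of Fatty-acid amide hydrolase 1 (Homo sapiens), with a stated time of 5 min (on this read-out higher numbers stand for weaker inhibition and lower numbers for stronger inhibition), compound 2 gives 2200 nM, the highest of the two numbers in hand. Its nearest neighbour, compound 1, `CCCCCCCCCCCC[S+]([O-])CC(=O)C(F)(F)F`, is a sulfoxide carrying a longer chain, and in this assay compound 1 gives 440 nM; the gap between the two lies beyond the scatter, but the two structures differ in more than one place, so the values show only that the longer-chain sulfoxide inhibits more strongly than the shorter-chain sulfone. Compound 3, `CCCCCCCCCCCCS(=O)(=O)CC(=O)C(F)(F)F`, keeps the sulfonyl group of compound 2 and differs from it by ethyl in place of hydrogen on a saturated chain carbon, ten or more bonds along the chain from a sulfonyl sulfur. Among the compounds with values here, no step between measured compounds isolates this change, so its size is open. Because compound 1 carries the same chain length and gives 440 nM, a gain in inhibition toward that number is expected, though a moderate one. For compound 3 the expected value in this assay is 1100 nM, with a range from 400 nM to 3000 nM. The expected step of a 2.0-fold lower number from compound 2 to compound 3 (0.30 log units; within the scatter) is thus a modest improvement, not far beyond the scatter.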

Compound 3, half-maximal inhibitory concentration: 250 nM
For compound 3 the middle estimate is 4.4-fold (0.64 log units) above the measured one; the measured number lies below the stated range.
By their numbers in this assay, from the lowest: compounds 3 and 1 (each within the scatter of the next); then compound 2.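

In this assay, within the data shown here, ethyl in place of hydrogen on a saturated chain carbon, ten or more bonds along the chain from a sulfonyl sulfur, gives an 8.8-fold lower number from compound 2 to compound 3 (0.94 log units; beyond the scatter); this is the first single-place step, and it shows that this position responds to lengthening of the chain while the sulfonyl group stays fixed. At the same chain length, compound 1 at 440 nM and compound 3 at 250 nM lie within the scatter of each other, so these numbers do not separate the sulfoxide from the sulfonyl group. No measurement in hand bears on the reason for the step.

On these data alone, a single step defines no trend along the chain, so it remains open whether a longer chain would give a still lower number in this assay or whether the number would turn back upward. Among these compounds, also open is how a phenyl ring or a carboxylic acid would read in place of the ethyl at this position, given that the series so far holds only saturated, unsubstituted chains.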